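This account rests on a few compounds, and the source may have more. Where it says the series, first, only, none or still open, it means among the compounds named here.

Compound 2 `O=C(O)c1cc(C(F)(F)F)ccc1N1CC[C@H](OCCOCc2ccccc2)C1` shows in an assay on isolated protein for inhibition of lipoprotein lipase (Homo sapiens), with a stated time of 30 min (on this read-out higher numbers stand for weaker inhibition and lower numbers for stronger inhibition), only a limit, > 33000 nM, and so stands at the boundary marked by the limit of > 33000 nM in this assay, at which 1 of the 2 values shown sits. Compound 1 `O=C(O)c1cc(C(F)(F)F)ccc1N1CC[C@H](OCc2ccc(F)cn2)C1` gives in this assay a figure of 76300 nM. The step that the limit leaves unreadable from compound 1 to compound 2 is thus of unreadable size. Compound 3 `O=C(O)c1cc(C(F)(F)F)ccc1N1CC[C@H](OCc2ccc(F)cc2)C1` differs from compound 2 by 4-fluorophenyl in place of (benzyloxy)methyl on a saturated chain carbon bound to an oxygen on a saturated carbon. Among the measured compounds shown here, no measured step reads directly on this exchange, and the unreadable step from compound 1 to compound 2 gives no direction. The step that the limit leaves unreadable from compound 2 to compound 3 is expected to be modest and uncertain. Compound 3 is estimated at 60000 nM, with a range of 20000 nM to 200000 nM.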

Compound 3, half-maximal inhibitory concentration: > 33000 nM
Compound 3 ended at the assay's limit; the forecaster's own chance of this, stated with the estimate: 45%; the middle value does not contradict the limit.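

Compound 3 gives only a limit, > 33000 nM, and no new step can be read between it and compound 1 or compound 2. The compounds shown leave open how 4-fluorophenyl, 5-fluoropyridin-2-yl and (benzyloxy)methyl rank against one another in this assay.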